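Benzyl to Phenyl: What to Expect from Compound 4

The source may report more compounds than this note shows. Statements on the series, on what has been measured and on what is new or still open speak of the compounds shown alone.

Compound 1, `O=C(Nc1ccc(OC(F)(F)F)c(Cl)c1)c1ccc(C(F)(F)F)cc1O`, 380 nM
Compound 2, `N#Cc1ccc(NC(=O)c2cc(Cc3ccccc3)ccc2O)cc1`, 1740 nM
Compound 3, `N#Cc1ccc(NC(=O)c2ccc(Br)cc2O)cc1Cl`, 440 nM

Of the compounds shown here, three have so far been tested in a functional assay on HL-60 cells (Homo sapiens) for cytotoxicity, read by luminescence and CellTiter-Glo, with a stated time of 3 days; on this read-out higher numbers stand for weaker inhibition and lower numbers for stronger inhibition. Compound 1 gives 380 nM, compound 3 gives 440 nM, and compound 2 gives 1740 nM. Of these three numbers, compound 2 stands highest, and its gaps to both compound 3 and compound 1 lie beyond the usual scatter, so it is the weakest inhibitor of the three that have been measured.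

Compound 4, `N#Cc1ccc(NC(=O)c2cc(-c3ccccc3)ccc2O)cc1`, has not yet been measured. It differs from compound 2 in one place: phenyl in place of benzyl on an aromatic carbon. The change sits on an aromatic carbon of a six-membered aromatic ring of carbon only, meta to a large group and para to a hydroxy group, and the entering phenyl has one heavy atom fewer than the departing benzyl.

Within the data shown here, no pair of measured compounds shows this same change, so its effect is unknown. The step of a 1.5-fold lower number from compound 2 to compound 4 (0.16 log units; within the scatter) is expected to be small, with at most a slight move toward a lower number, and quite possibly nothing beyond the scatter. Compound 4 is therefore estimated at 1200 nM, with a range from 350 nM to 4000 nM.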

Compound 4, half-maximal inhibitory concentration: 1350 nM
Compound 4: the middle estimate sits 1.1-fold (0.05 log units) below what was measured, and the stated range covers the measured number.
By their numbers in this assay, from the lowest: compounds 1 and 3 (each within the scatter of the next); then compounds 4 and 2 (each within the scatter of the next).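

In this assay, putting phenyl in place of benzyl on this aromatic carbon, meta to a large group and para to a hydroxy group, gives a 1.3-fold lower number from compound 2 to compound 4 (0.11 log units; within the scatter) and so leaves the two compounds indistinguishable on this read-out. This is the first pair shown that differs in one place only, and it shows that, in this one pair, dropping a single carbon atom from the substituent and leaving the ring in place produces no difference beyond the scatter. No measurement at hand explains why the two groups read alike.

Benzyl and phenyl are close relatives, each carrying one six-membered aromatic ring of carbon only with no hydrogen-bond donors or acceptors, so this pair samples only a narrow slice of what this position might accept, and an amine, a carboxylic acid or a longer chain ending in a phenyl ring on the same carbon could read quite differently. On these data alone, whether the same swap would also read alike on the cores of compound 1 or compound 3, which carry other groups at several places, also stays open.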